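The source may hold more compounds than are shown below. What is called first, only, known or untested is meant among the compounds shown, and "the series" means these compounds.

Compound 1 `CCOC(=O)[C@]1(C(=O)Nc2ccccc2)C[C@H]1c1cc(OC)c(OC)c(OC)c1`: > 100000 nM (a limit)
Compound 2 `CCOC(=O)[C@@]1(C(=O)Nc2ccccc2Cl)C[C@@H]1c1cc(OC)c(OC)c(OC)c1`: > 100000 nM (a limit)

Both results come from a functional assay on HeLa cells (Homo sapiens) for cytotoxicity, read by MTT assay, with a stated time of 48 h; on this read-out lower numbers stand for stronger inhibition and higher numbers for weaker inhibition. Compound 2 gives > 100000 nM, which is a limit of the assay and not a number. Compound 1 gives > 100000 nM, which is also a limit. Together they make up the whole picture so far: the limit of > 100000 nM in this assay, at which 2 of the 2 values shown sit. Neither compound has a numerical value, so compound 2 can be placed only at this limit.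

The next compound is compound 3 `CCOC(=O)[C@]1(C(=O)Nc2ccccc2Cl)C[C@H]1c1cc(OC)c(OC)c(OC)c1`. Its relation to compound 2 is the two compounds have the same atoms and bonds and differ only in configuration as drawn: 2 of 2 stereo elements differ (all stereocentres are inverted: mirror images); a stereocentre at a saturated ring carbon is drawn S in compound 2 and R in compound 3; a stereocentre at a saturated ring carbon is drawn R in compound 2 and S in compound 3. Among the compounds with values here, no measured step yet shows what such an inversion does in this assay, so any forecast has little to stand on. The forecast rests on compound 2, whose limit is > 100000 nM. The expected change a number no higher from compound 2 to compound 3 (the limit leaves the size open) is none beyond the scatter, with neither direction favoured. Compound 3 may well be reported only as a limit too. For compound 3 the estimated value is 100000 nM, with an expected range of 30000 nM to 200000 nM.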

Compound 3, half-maximal inhibitory concentration: 42400 nM
The estimate for compound 3 lay 2.4-fold (0.37 log units) above the measured number, within the range that was stated.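

In this assay, within the data shown here, compound 3 gives 42400 nM, the only true number among the values shown, so this series can register a number in the read-out. Inverting both stereocentres brings an at least 2.3-fold lower number from compound 2 to compound 3 (0.37 log units; beyond the scatter), which shows that the mirror-image form matters at this chloro-bearing compound, and no other structural change can account for the difference: the fact that compounds 2 and 3 differ only in the configuration as drawn. Chloro in place of hydrogen on an aromatic carbon brings an at least 2.3-fold lower number from compound 1 to compound 3 (0.37 log units; beyond the scatter), so within the configuration drawn for compound 3, this single added atom also separates a measured value from a limit.

On these data alone, the true size of both steps stays open, since each starts from a limit rather than a number: the limit of > 100000 nM in this assay, at which 2 of the 3 values shown sit. Also open, as far as these compounds go, is whether a fluoro or a methoxy group in place of the chloro, or a carboxylic acid in place of the ethyl ester, would lower the number further in this assay, and whether the same mirror-image difference would hold for those compounds.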